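Methylation of a Ring Nitrogen in an Inactive Sulfonamide

The compounds below may be only part of what the source reports. "The series", "measured", "known", "first", "only" and "open" are said of these compounds alone.

Compound 1 `Cc1ccc(S(=O)(=O)Nc2cc[nH]c(=O)n2)cc1` was tested in a functional assay on HeLa cells (Homo sapiens) for inhibition, read by MTT assay, with a stated time of 72 h; a higher number here means a weaker inhibitor, a lower number a stronger inhibitor. In this assay compound 1 gives > 100000 nM, which is a limit of the assay and not a number. Compound 2 `O=c1[nH]c(=O)n(COC(CO)CO)cc1O` likewise gives in this assay > 100000 nM, again a limit. Compound 3 `CSc1cc[nH]c(=O)n1` gives in this assay > 100000 nM, also a limit. Going by the values given here, all three values sit at the limit of > 100000 nM in this assay, at which 3 of the 3 values shown sit, so no step between measured compounds can be read from them. Compound 4 `Cc1ccc(S(=O)(=O)Nc2ccn(C)c(=O)n2)cc1` differs from compound 1 in one place: methyl in place of hydrogen on an aromatic nitrogen. With every measured value at the limit, the step that the limit leaves unreadable from compound 1 to compound 4 is expected to be none beyond the scatter. Compound 4 is therefore estimated at 150000 nM, with a range from 40000 nM to 500000 nM, and most likely only a limit will again be reported.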

Compound 4, half-maximal inhibitory concentration: > 100000 nM
Compound 4: no number, only a limit; the forecaster's own chance of this, stated with the estimate: 85%; the middle value does not contradict the limit.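

No step from compound 1 to compound 4 can be read, because both values are limits: the limit of > 100000 nM in this assay, at which 4 of the 4 values shown sit.

The compounds shown leave open what effect the methyl has and which structure would give a measurable value in this assay.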